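A few compounds are considered here, and "the series" means these few. Any claim that something is new, unique, unknown or untested is made for them only; others in the source may bear on it.

Values so far in an ADME assay on Vero cells (Chlorocebus sabaeus) for cytotoxicity, read by MTT assay; on this read-out higher numbers stand for lower toxicity in this test and lower numbers for higher toxicity in this test:
- compound 1 `COC(=O)c1ccccc1-n1nc(C(F)(F)F)cc1C(=O)Nc1ccc(S(=O)(=O)N2CCCC2)cc1` gives "not determined" (no result reported)
- compound 2 `O=C(O)c1ccccc1-n1nc(C(F)(F)F)cc1C(=O)Nc1ccc(S(=O)(=O)N2CCCC2)cc1` gives "not determined" (no result reported)
- compound 3 `Cn1nc(C(F)(F)F)cc1C(=O)Nc1ccc(S(=O)(=O)NC2CCCCC2)cc1` gives 15000 nM

Going by the values given here, compound 3 carries the only number in this assay, so it cannot yet be ranked against anything. Compound 4 (`Cn1nc(C(F)(F)F)cc1C(=O)Nc1ccc(S(=O)(=O)N2CCCC(C(=O)O)C2)cc1`) has 3-carboxypiperidin-1-yl in place of cyclohexylamino on a sulfonyl sulfur. Among the compounds with values here, no measured pair shows what such a change does, so the expectation rests on this structural change and on compound 3 at 15000 nM alone. A moderate move towards higher numbers is expected, and the estimated 2.7-fold higher number from compound 3 to compound 4 (0.43 log units; beyond the scatter) remains uncertain. For compound 4 the estimated value is 40000 nM, with an expected range from 12000 nM to 130000 nM.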

Compound 4, half-maximal cytotoxic concentration: > 300000 nM
Compound 4: no number, only a limit; the forecaster's own chance of this, stated with the estimate: 40%; middle value at least 7.5-fold (0.87 log units) from the limit.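

In this assay, 3-carboxypiperidin-1-yl in place of cyclohexylamino on a sulfonyl sulfur gives an at least 20-fold higher number from compound 3 to compound 4 (1.30 log units; beyond the scatter). Going by these compounds alone, this is the only step readable, and it shows that a change at this place alone can move the read-out by a large margin. As far as these compounds go, its full size stays unknown, since compound 4 reads only as a limit of the assay: the limit of > 300000 nM in this assay, at which 1 of the 4 values shown sits.

Open, from the compounds shown here alone, is whether the carboxylic acid or the piperidine ring carries the step; plain piperidin-1-yl and the methyl ester of the acid would separate the two. Also open, going by these compounds, is whether an amine on the same ring would behave alike.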